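This account rests on a few compounds, and the source may have more. Where it says the series, first, only, none or still open, it means among the compounds named here.

Within the data shown here, in an ADME assay on HEK-293T cells (Homo sapiens) for cytotoxicity, read by MTT assay, with a stated time of 48 h, in the absence of a further agent (a lower number here means a stronger inhibitor, a higher number a weaker inhibitor), compound 2 `O=C(Nc1ccccc1)c1csc(-c2c[nH]c3ccccc23)n1` gives 41100 nM, the only plain number in this small set. Compound 1 `O=C(NCc1ccccc1)c1csc(-c2c[nH]c3ccccc23)n1` gives only a limit in this assay, > 100000 nM, which is the limit of > 100000 nM in this assay, at which 1 of the 2 values shown sits. Among the measured compounds shown here, the single measured step, an at least 2.4-fold lower number from compound 1 to compound 2 (0.38 log units; beyond the scatter), came from putting phenyl in place of benzyl on the amide-type nitrogen. Compound 3 `Cc1ccc(NC(=O)c2csc(-c3c[nH]c4ccccc34)n2)cc1` differs from compound 2 by methyl in place of hydrogen on an aromatic carbon, read one bond further out as phenyl to 4-methylphenyl. For the measured compounds named here, no measured step touches this kind of change, so no shift beyond the scatter is expected in this assay. Compound 3 is therefore expected near 40000 nM, with a range from 15000 nM to 100000 nM. For compound 3 that expectation means a step of a 1.0-fold lower number from compound 2 to compound 3 (0.01 log units; within the scatter).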

Compound 3, half-maximal inhibitory concentration: > 100000 nM
Compound 3 ended at the assay's limit (the forecaster's own chance of this, stated with the estimate: 25%); middle value at least 2.5-fold (0.39 log units) from the limit.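

Swapping one hydrogen on this aromatic ring for methyl is not a silent change in this assay: the result is an at least 2.4-fold higher number from compound 2 to compound 3 (0.38 log units; beyond the scatter). The value of compound 3 is a limit, and the step between compound 1 and compound 3 cannot be read. Only compound 2 now keeps a plain number, while the other two stand at the same limit: the limit of > 100000 nM in this assay, at which 2 of the 3 values shown sit.

On these data alone, whether this shift is particular to methyl stays open. An amine, a chlorine or a carboxylic acid at the same place on the ring could separate methyl from other groups.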